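Changing the amide group on a weakly antiproliferative core

The source may hold more compounds than are shown below. What is called first, only, known or untested is meant among the compounds shown, and "the series" means these compounds.

Compound 3 `Cn1cc(-c2nn(Cc3ccc(C(=O)N4CCCCC4)cc3)c(=O)c3ccccc23)cn1` carries a piperidin-1-yl group on a carbonyl carbon that is joined to an aromatic carbon. In a functional assay on HepG2 cells (Homo sapiens) for antiproliferative activity, read by MTT assay, with a stated time of 72 h (on this read-out lower numbers stand for stronger inhibition and higher numbers for weaker inhibition), compound 3 gives 73100 nM. Among the numbers shown, compound 3 stands lowest, and its nearest neighbour is compound 1 `Cc1noc(C)c1-c1nn(Cc2ccc(C(=O)N3CCCCC3)cc2)c(=O)c2ccccc12`, which in this assay gives 97300 nM, a gap of a 1.3-fold lower number from compound 1 to compound 3 (0.12 log units; within the scatter). Compound 2 `Cc1noc(C)c1-c1nn(Cc2ccc(C(=O)NC3CCCC3)cc2)c(=O)c2ccccc12` reaches only a limit of the assay, > 100000 nM.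

Compound 4 `Cn1cc(-c2nn(Cc3ccc(C(=O)NC4CC(C)(C)N([O])C(C)(C)C4)cc3)c(=O)c3ccccc23)cn1` has not yet been measured. It differs from compound 3 in one place: a group of 12 heavy atoms (9 carbon, 2 nitrogen, 1 oxygen; one six-membered non-aromatic ring with 1 hetero atom) in place of a group of 6 heavy atoms (5 carbon, 1 nitrogen; one six-membered non-aromatic ring with 1 hetero atom), on a carbonyl carbon. The measured step that bears on this change is the one in which cyclopentylamino replaced piperidin-1-yl on the carbonyl carbon, giving an at least 1.0-fold higher number from compound 1 to compound 2 (0.01 log units; that floor lies within the scatter), in line with the limit of > 100000 nM in this assay, at which 1 of the 3 values shown sits. That earlier step replaced the same piperidin-1-yl group and brought no gain. Going by the values given here, the group entering compound 4 is different again, and no measured step here covers it.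

Compound 4 is therefore expected to show a step of about a 1.3-fold higher number from compound 3 to compound 4 (0.11 log units; within the scatter), which may stay within the scatter or drift toward weaker inhibition. The estimated value for compound 4 is 95000 nM, with a range from 40000 nM to 220000 nM. A limit rather than a number is a real possibility.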

Compound 4, half-maximal inhibitory concentration: 27400 nM
Compound 4: middle estimate off by 3.5-fold (0.54 log units), on the high side; measured number below the stated range.
By their numbers in this assay, from the lowest: compound 4; then compounds 3 and 1 (each within the scatter of the next). At a limit, above all of these: compound 2.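

In this assay, the carbonyl carbon turns out to be a place where a change can move the number beyond the scatter: a 2.7-fold lower number from compound 3 to compound 4 (0.43 log units; beyond the scatter). The earlier swap of the pyrazole and oxazole groups stayed within the scatter, so this is the first clear step among the compounds shown, although it is modest and compound 4 still gives 27400 nM. The only earlier change at this carbon cannot be sized, because compound 2 is a limit and not a number: the limit of > 100000 nM in this assay, at which 1 of the 4 values shown sits.

The entering group differs from piperidin-1-yl in size, in its amide hydrogen and in its oxygen-bearing ring nitrogen, and the data do not tell which of these features accounts for the step. On these data alone, a plain cyclohexylamino group, or a 2,2,6,6-tetramethylpiperidin-4-ylamino group with no oxygen on its ring nitrogen, would help separate them, and it also remains open whether the same entering group would give a similar step on compound 1, which carries 3,5-dimethyl-1,2-oxazol-4-yl.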